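Swapping Chloro for Methoxy: An Expected Seizure-Protection Dose

This account rests on a few compounds, and the source may have more. Where it says the series, first, only, none or still open, it means among the compounds named here.

Compound 1 `CC(=O)N1N=C(Nc2nc3ccccc3s2)CC1c1ccc(Cl)cc1` — 209 umol/kg
Compound 2 `O=C(/C=C/c1ccccc1)Nc1nc2ccc([N+](=O)[O-])cc2s1` — 485 umol/kg
Compound 3 `CC(=O)N1N=C(Nc2nc3ccc([N+](=O)[O-])cc3s2)CC1c1ccc(Cl)cc1` — 132 umol/kg

Of the compounds shown here, three sharing one core have been measured in a functional assay on the whole organism (Hindlimb, strain albino) with Mus musculus as the target, in the maximal electroshock model, with a stated time of 0.5 h; on this read-out lower numbers stand for an effect already at smaller amounts and higher numbers for an effect only at larger amounts of compound. Compound 1 gives 209 umol/kg, the second highest of the three numbers. Its nearest neighbour is compound 3, which gives 132 umol/kg; the step of a 1.6-fold lower number from compound 1 to compound 3 (0.20 log units; within the scatter) lies within the scatter, so the two cannot be told apart. Compound 2, which differs from the other two in several places, gives 485 umol/kg, a gap from compound 1 that lies beyond the scatter.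

Compound 4 `COc1ccc(C2CC(Nc3nc4ccccc4s3)=NN2C(C)=O)cc1` has not yet been measured. It arises from compound 1 by a single change: methoxy in place of chloro on an aromatic carbon. Within the data shown here, none of the measured steps touches this part of the molecule: the one step between compounds differing in a single place, from compound 1 to compound 3, concerns another group and was itself within the scatter. There is therefore no measured guide to the direction of this change, and the expectation rests on the shared core alone.

Compound 4 is expected to give about 210 umol/kg in this assay, within the range 100 umol/kg to 450 umol/kg. The step of a 1.0-fold higher number from compound 1 to compound 4 (0.00 log units; within the scatter) is expected to stay within the scatter, in neither direction.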

Compound 4, dose for half-maximal effect: 226 umol/kg
For compound 4 the middle estimate is 1.1-fold (0.03 log units) below the measured one, and the stated range covers the measured number.
By their numbers in this assay, from the lowest: compounds 3, 1 and 4 (each within the scatter of the next); then compound 2.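

In this assay, among these compounds, replacing 4-chlorophenyl with 4-methoxyphenyl gives a 1.1-fold higher number from compound 1 to compound 4 (0.03 log units; within the scatter), which is the first measured step at this position, on an aromatic carbon para to a large group. The step lies within the scatter, so this swap cannot be told apart from no change at all, even though methoxy brings an oxygen and a hydrogen-bond acceptor that chloro lacks. No measurement is available that would explain this outcome.

As far as these compounds go, a single swap says little about the position as a whole, so it remains open whether a group of another kind here, such as an amine, a carboxylic acid or a longer chain like butoxy, would move the number beyond the scatter. From the compounds shown here alone, it also remains open whether methoxy in place of chloro would read the same on the nitro-bearing core of compound 3, where the nitro group itself gave only a 1.6-fold lower number from compound 1 to compound 3 (0.20 log units; within the scatter).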